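Carboxy in place of aminomethyl on the outer ring

The source may report more compounds than this note shows. Statements on the series, on what has been measured and on what is new or still open speak of the compounds shown alone.

Compound 1 `O=C(COc1ccc2c(=O)ccoc2c1)Nc1cccc(NC(=O)c2ccccc2)c1` gives 120 nM in an assay on isolated protein for inhibition of Rho-associated protein kinase 1 (Homo sapiens), read by scintillation counting, radiometric assay and 33P incorporation, with a stated time of 40 min, in the presence of a further agent that is not named here; a higher number here means a weaker inhibitor, a lower number a stronger inhibitor. Compound 2 `NCc1ccc(C(=O)Nc2cccc(NC(=O)COc3ccc4c(=O)ccoc4c3)c2)cc1` carries an aminomethyl group on the outer ring, and in this assay compound 2 gives 532 nM. Among the two numbers so far compound 2 stands highest; its nearest neighbour is compound 1, and the step reads a 4.4-fold higher number from compound 1 to compound 2 (0.65 log units; beyond the scatter). Compound 3 `O=C(COc1ccc2c(=O)ccoc2c1)Nc1cccc(NC(=O)c2ccc(C(=O)O)cc2)c1` is not yet measured; the change is carboxy in place of aminomethyl on an aromatic carbon. For the measured compounds named here, no measured step exchanges one substituent for another at this carbon. Only a 4.4-fold higher number from compound 1 to compound 2 (0.65 log units; beyond the scatter) bears on the question, and it shows that placing a group at this position moved the number upward, beyond the scatter. For compound 3 the expected step in this assay is a 1.3-fold lower number from compound 2 to compound 3 (0.12 log units; within the scatter), with the direction uncertain. Compound 3 is estimated at 400 nM in this assay, within a range from 120 nM to 1500 nM.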

Compound 3, half-maximal inhibitory concentration: 6890 nM
Compound 3: the middle estimate sits 17-fold (1.24 log units) below what was measured; the whole stated range lies below it.
By their numbers in this assay, from the lowest: compound 1; then compound 2; then compound 3.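

In this assay, for the compounds shown here, the identity of the group on this carbon counts, not only its presence: carboxy in place of aminomethyl gives a 13-fold higher number from compound 2 to compound 3 (1.11 log units; beyond the scatter), whereas the earlier compounds showed only the effect of adding aminomethyl. Set against the unsubstituted outer ring, carboxy gives a 57-fold higher number from compound 1 to compound 3 (1.76 log units; beyond the scatter), so both groups tried at this carbon raise the number beyond the scatter, and neither of them matches compound 1. Nothing available accounts for the gap between aminomethyl and carboxy.

Open, from the compounds shown here alone, is whether a methyl ester, a primary amide or a longer chain ending in an amine would stay closer to compound 1 at this carbon. Also open, going by these compounds, is whether any group here, such as fluoro or methoxy, would give a lower number than compound 1.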